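Replacing a Lactam with a Hydroxyalkyl Group on the Amide

The compounds below may be only part of what the source reports. "The series", "measured", "known", "first", "only" and "open" are said of these compounds alone.

Measured compounds:
compound 1, `CC1(C)Cc2c(sc(NC(=O)c3ccccc3O)c2C(N)=O)CO1`: 13 nM
compound 2, `CC1(C)Cc2c(sc(NC(=O)C3CNC(=O)C3)c2C(N)=O)C(C)(C)O1`: > 10000 nM

In an assay on cells for positive allosteric modulation of Cystic fibrosis transmembrane conductance regulator variant F508del (Homo sapiens), with stated times of 10 min and 7 s, in the presence of a further agent that is not named here (on this read-out higher numbers stand for an effect only at larger amounts of compound and lower numbers for an effect already at smaller amounts), compound 1 gives 13 nM. For compound 2 only a limit of the assay is recorded, > 10000 nM, which is the limit of > 10000 nM in this assay, at which 1 of the 2 values shown sits. Compound 2 thus stands at the weak end of the numbers shown. Compound 3, `CC1(C)Cc2c(sc(NC(=O)[C@H](O)C(C)(C)C)c2C(N)=O)C(C)(C)O1`, differs from compound 2 by 1-hydroxy-2,2-dimethylpropyl in place of 5-oxopyrrolidin-3-yl on a carbonyl carbon. Among the measured compounds shown here, no step between two measured compounds exists to size this change, so the expectation rests on the limit of compound 2 alone. A move toward smaller amounts is expected, an at least 3.3-fold lower number from compound 2 to compound 3 (0.52 log units; beyond the scatter). Compound 3 is estimated at 3000 nM, within a range from 300 nM to 30000 nM.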

Compound 3, half-maximal effective concentration: 127 nM
For compound 3 the middle estimate is 24-fold (1.37 log units) above the measured one; the measured number lies below the stated range.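

On a carbonyl carbon whose other neighbour is an amide-type nitrogen, activity depends strongly on the group attached: 1-hydroxy-2,2-dimethylpropyl in place of 5-oxopyrrolidin-3-yl, with no ring but the same counted donors and acceptors, gives an at least 78-fold lower number from compound 2 to compound 3 (1.89 log units; beyond the scatter). Compound 2 carries only a limit, so this step has no fixed upper size: the limit of > 10000 nM in this assay, at which 1 of the 3 values shown sits.

The compounds shown leave open whether the hydroxy group, the branched chain or the defined stereocentre accounts for the step. An amine in place of the hydroxy group, or the opposite stereocentre, would help to separate these.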